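Chloro Substitution on the Anilide Ring of a Dithiol Amide

This account rests on a few compounds, and the source may have more. Where it says the series, first, only, none or still open, it means among the compounds named here.

Measured so far:
compound 1, `O=C(CCCCC(S)CCS)Nc1ccccc1`, 3.72%
compound 2, `O=C(CCCCC(S)CCS)Nc1cccc(Cl)c1`, 3.22%

In a functional assay on Bel-7402 cells (Homo sapiens) for inhibition, read by MTT assay, with a stated time of 24 h, tested at 10 ug/mL (on this read-out higher numbers stand for more inhibition of growth at the one concentration tested and lower numbers for less inhibition of growth), compound 1 gives 3.72%, the highest of the two numbers shown, though compound 2 lies within the scatter of it, as the step of a number 0.5 percentage points lower from compound 1 to compound 2 (within the scatter) shows. Compound 3, `O=C(CCCCC(S)CCS)Nc1ccc(Cl)cc1`, has not yet been measured. It differs from compound 1 by chloro in place of hydrogen on an aromatic carbon. Among the measured compounds shown here, the only measured step that bears on this change is the one from compound 1 to compound 2, a number 0.5 percentage points lower from compound 1 to compound 2 (within the scatter), where the same group enters at another place on the same ring and the number stays within the scatter. Compound 3 is therefore expected to show no step beyond the scatter in this assay, with an expected step of a number 0.2 percentage points lower from compound 1 to compound 3 (within the scatter). The estimate for compound 3 in this assay is 3.5%, with a range from -5% to 12%.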

Compound 3, percent growth inhibition at one concentration: 1.16%
Compound 3: the middle estimate sits 2.3 percentage points above what was measured, within the range that was stated.
By their numbers in this assay, from the lowest: compounds 3, 2 and 1 (each within the scatter of the next).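

In this assay, among the compounds shown here, chloro placed para to a large group gives a number 2.6 percentage points lower from compound 1 to compound 3 (within the scatter), so this place on the ring, like the one occupied in compound 2, shows no step beyond the scatter. With the same change now read at two places on the ring, neither separates its compound from compound 1, and the position of the chloro group makes no difference that this read-out can resolve at the one concentration tested. Nothing shown here gives a reason for this result.

Still open, going by these compounds, is whether a different group at this same place, such as an amine, a methoxy group or a carboxylic acid, would give a step beyond the scatter. Also open, on these data alone, is whether a longer chain between the amide and the two thiol groups would alter the number.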